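The source may hold more compounds than are shown below. What is called first, only, known or untested is meant among the compounds shown, and "the series" means these compounds.

Of the compounds shown here, three that share one core have been tested in an ADME assay on HEK293 cells (Homo sapiens) for cytotoxicity, read by CellTiter-Glo and resazurin assay, with a stated time of 72 h; on this read-out lower numbers stand for an effect already at smaller amounts and higher numbers for an effect only at larger amounts of compound. Compound 1 `CCOC(=O)CCCCCOc1cccc(CN(C(=O)c2ccc(-c3ccncc3)cc2)C(C)C)c1` carries a pyridin-4-yl group on an aromatic carbon. In this assay compound 1 reaches only a limit of the assay, > 26000 nM. Compound 2 `CCOC(=O)CCCCCOc1cccc(CN(C(=O)c2ccc(-c3cccc(C(C)=O)c3)cc2)C(C)C)c1` carries a 3-acetylphenyl group in that place. In this assay compound 2 likewise stops at a limit, > 26000 nM. Compound 3 `CCOC(=O)CCCCCOc1cccc(CN(C(=O)c2ccc(-c3ccc(C(C)=O)s3)cc2)C(C)C)c1` carries a 5-acetylthiophen-2-yl group there. In this assay compound 3 also gives only a limit, > 26000 nM. Compound 3 thus stands exactly where the other two stand, at the limit of > 26000 nM in this assay, at which 3 of the 3 values shown sit, with no number to set it apart from them. The steps leading to it carry no readable size: a step that the two limits leave unreadable from compound 1 to compound 3 and a step that the two limits leave unreadable from compound 2 to compound 3 show neither direction nor extent, and the same holds for a step that the two limits leave unreadable from compound 1 to compound 2.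

Compound 4 `CCOC(=O)CCCCCOc1cccc(CN(C(=O)c2ccc(-c3ccc(Cl)c(Cl)c3)cc2)C(C)C)c1` has not yet been measured. Its change from compound 3 is 3,4-dichlorophenyl in place of 5-acetylthiophen-2-yl on an aromatic carbon. The two groups match in counted heavy atoms, so the change is a swap of one aromatic ring for another of like size. Since every measured step sits at a limit, no step beyond the scatter is expected here. Compound 4 is therefore estimated to give 40000 nM, within 15000 nM to 100000 nM. The step this estimate implies, a step that the limit leaves unreadable from compound 3 to compound 4, is expected to be none beyond the scatter, most likely ending again at a limit.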

Compound 4, half-maximal effective concentration: > 26000 nM
Compound 4 was reported as a limit (the forecaster's own chance of this, stated with the estimate: 80%); the middle value lies beyond the limit too.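

In this assay compound 4 also gives only a limit of the assay, > 26000 nM. Its steps from compound 1, compound 2 and compound 3 cannot be read in size or direction, and all four compounds stand together: the limit of > 26000 nM in this assay, at which 4 of the 4 values shown sit. The compounds shown leave open whether any group in this place would give a measurable effect on these cells, and at what concentration.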